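Swapping the aryl group on the core: compound 3 to compound 4

This account rests on a few compounds, and the source may have more. Where it says the series, first, only, none or still open, it means among the compounds named here.

Compound 1, `Cc1cnc(Nc2ccc(N3C[C@@H](C)O[C@@H](C)C3)nc2)nc1-c1ccc(OC(F)(F)F)cc1`, gives > 500 nM; compound 2, `Cc1ccccc1C(=O)Nc1ccc(Nc2ncc(C)c(-c3ccc(OC(F)(F)F)cc3)n2)cc1`, gives 42.1 nM; compound 3, `Cc1cnc(Nc2ccc(C(=O)Nc3c(C)cccc3C)cc2)nc1-c1ccc(OC(F)(F)F)c(F)c1`, gives 159 nM.

These values come from an assay on NIH3T3 cells for inhibition of Sonic hedgehog protein (Mus musculus), read by a luciferase reporter, with a stated time of 48 h; on this read-out lower numbers stand for stronger inhibition and higher numbers for weaker inhibition. For compound 1 the value is a limit of the assay, not a number. Among the two numbers shown, compound 3 stands highest, with compound 2 the nearest, beyond the scatter. Among the measured compounds shown here, the measured compounds differ from one another in more than one place, so no single step between them can be set apart.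

Compound 4, `Cc1cnc(Nc2ccc(C(=O)Nc3c(C)cccc3C)cc2)nc1-c1ccccc1`, differs from compound 3 by one change: phenyl in place of 3-fluoro-4-(trifluoromethoxy)phenyl on an aromatic carbon. The phenyl that enters carries none of the fluorine of the group that leaves and has no hydrogen-bond acceptor. Since compound 3 is already the highest number, the expected direction of the step from compound 3 to compound 4 is toward a higher number, of a size that may lie beyond the scatter, as a 3.1-fold higher number from compound 3 to compound 4 (0.50 log units; beyond the scatter) states. Compound 4 is estimated at 500 nM, with a likely range from 120 nM to 2000 nM, and there is a fair chance that this assay returns only a limit for it.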

Compound 4, half-maximal inhibitory concentration: 1.3 nM
Estimate against measurement, compound 4: 380-fold (2.59 log units) above; the whole stated range lies above it.
By their numbers in this assay, from the lowest: compound 4; then compound 2; then compound 3. At a limit, above all of these: compound 1.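

Among the compounds shown here, the step gives the first reading of a single change on the shared core: in this assay, there is a 120-fold lower number from compound 3 to compound 4 (2.09 log units; beyond the scatter), on replacing 3-fluoro-4-(trifluoromethoxy)phenyl with phenyl. It shows that at this aromatic carbon, next to the ring nitrogen and ortho to a methyl group, neither the fluorine nor the hydrogen-bond acceptor of the group that leaves is required for a low number, at least with this amide in place. Nothing in the data shown accounts for the size of this step.

On these data alone, the change removes the fluorine and the trifluoromethoxy group together, so it remains open whether either alone carries the difference, which a phenyl bearing only a fluorine or only a methoxy group would help to separate. As far as these compounds go, it also remains open how a pyridine ring or an aminophenyl group would fare at this position.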